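A few compounds are considered here, and "the series" means these few. Any claim that something is new, unique, unknown or untested is made for them only; others in the source may bear on it.

Measured compounds:

Compound 1, `CO[C@@]1(C(=O)O)C=C[C@@H](NC(C)=O)[C@H]([C@H](O)[C@H](O)CO)O1`: in an assay on HEK293 cells for inhibition of sialidase-3 (Homo sapiens), read by fluorescence, with a stated time of 1 h (a lower number here means a stronger inhibitor, a higher number a weaker inhibitor), compound 1 gives > 1000000 nM, which is a limit of the assay and not a number.
Compound 2, `CCS[C@]1(C(=O)O)C=C[C@@H](NC(C)=O)[C@H]([C@H](O)[C@H](O)CO)O1`: compound 2 gives > 1000000 nM, again a limit and not a number.
Compound 3, `CCO[C@@]1(C(=O)O)C=C[C@@H](NC(C)=O)[C@H]([C@H](O)[C@H](O)CO)O1`: compound 3 gives > 1000000 nM, once more a limit rather than a number.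

Going by the values given here, compound 3 therefore stands exactly where the other two measured compounds stand: every value shown is a limit, and no compound can be set above or below another. Among the compounds with values here, the single step between measured compounds that differ in one place, a step that the two limits leave unreadable from compound 1 to compound 3, has no readable size because the limit of > 1000000 nM in this assay, at which 3 of the 3 values shown sit, holds both of its ends.

The unmeasured compound is compound 4, `CCCCO[C@@]1(C(=O)O)C=C[C@@H](NC(C)=O)[C@H]([C@H](O)[C@H](O)CO)O1`. Its difference from compound 3 is ethyl in place of hydrogen on a saturated chain carbon, two bonds along the chain from an oxygen on a saturated carbon. Within the data shown here, the only measured step that bears on this change is a step that the two limits leave unreadable from compound 1 to compound 3, and it is unreadable; every value shown sits at the limit described by the limit of > 1000000 nM in this assay, at which 3 of the 3 values shown sit. Nothing in the numbers therefore points to a step in either direction beyond the scatter, and the step of a number no higher from compound 3 to compound 4 (the limit leaves the size open) is expected to be none that can be seen. The estimate for compound 4 in this assay is 1000000 nM, with a range from 100000 nM to 10000000 nM, most likely reported once more as a limit rather than a number.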

Compound 4, half-maximal inhibitory concentration: > 1000000 nM
Compound 4 was reported as a limit; the forecaster's own chance of this, stated with the estimate: 85%; the middle value lies on the limit itself.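

In this assay compound 4 gives > 1000000 nM, which is a limit and not a number. No new step can be read from compound 3 to compound 4 or from compound 1 to compound 4, because both ends of each pair rest on the same limit: the limit of > 1000000 nM in this assay, at which 4 of the 4 values shown sit. The compounds shown leave open how strongly any of them inhibits the enzyme, so the effect of lengthening the chain from ethoxy to butoxy remains unknown.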